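From an Aryl Amide to a Ring-Free Amide

A few compounds are considered here, and "the series" means these few. Any claim that something is new, unique, unknown or untested is made for them only; others in the source may bear on it.

In a functional assay on PC-3 cells (Homo sapiens) for antiproliferative activity, read by MTT assay, with a stated time of 48 h (on this read-out lower numbers stand for stronger inhibition and higher numbers for weaker inhibition), compound 1 `CCN(CC)CCNC(=O)c1ccc(C(CC)(CC)c2ccc(OCCC(O)(CC)CC)c(C)c2)n1CC` gives 3350 nM and compound 2 `C=CCN(C)C(=O)c1ccc(C(CC)(CC)c2ccc(OCCC(O)(CC)CC)c(C)c2)n1CC` gives 12800 nM. Compound 3 `CCn1c(C(=O)Nc2ccc(OC(F)(F)F)cc2)ccc1C(CC)(CC)c1ccc(OCCC(O)(CC)CC)c(C)c1` stands at > 50000 nM, which is a limit of the assay and not a number. Compound 4 `CCOC(=O)C(CC(=O)OC)NC(=O)c1ccc(C(CC)(CC)c2ccc(OCCC(O)(CC)CC)c(C)c2)n1CC` differs from it on an amide-type nitrogen: a group of 11 heavy atoms (7 carbon, 4 oxygen; no ring) in place of a group of 11 heavy atoms (7 carbon, 1 oxygen, 3 fluorine; one six-membered aromatic ring of carbon only), on an amide-type nitrogen. Two measured steps lead to the group that leaves, the large at least 14-fold higher number from compound 1 to compound 3 (1.17 log units; beyond the scatter) and the at least modest an at least 3.9-fold higher number from compound 2 to compound 3 (0.59 log units; beyond the scatter). Both point to a lower number in this assay once 4-(trifluoromethoxy)phenyl is replaced, though neither step involves the entering group. The estimate amounts to an expected at least 2.2-fold lower number from compound 3 to compound 4 (0.35 log units; beyond the scatter). Compound 4 is expected at 22000 nM, within an estimated range of 8000 nM to 50000 nM.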

Compound 4, half-maximal inhibitory concentration: 5840 nM
For compound 4 the middle estimate is 3.8-fold (0.58 log units) above the measured one; measured number outside the range, below it.
By their numbers in this assay, from the lowest: compounds 1 and 4 (each within the scatter of the next); then compound 2. At a limit, above all of these: compound 3.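

The diethylamino group of compound 1 is not required on this amide-type nitrogen: the ring-free group of compound 4, with carbon and oxygen only, gives a 1.7-fold higher number from compound 1 to compound 4 (0.24 log units; within the scatter) and, against the allyl(methyl)amino amide, a 2.2-fold lower number from compound 2 to compound 4 (0.34 log units; beyond the scatter) in this assay. Replacing 4-(trifluoromethoxy)phenyl gives an at least 8.5-fold lower number from compound 3 to compound 4 (0.93 log units; beyond the scatter) as well. From the compounds shown here alone, compound 3 is a limit and not a number, so the true size of that step stays open: the limit of > 50000 nM in this assay, at which 1 of the 4 values shown sits.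

Going by these compounds, whether both ester groups of compound 4 are needed remains open. A carboxylic acid in their place could settle this.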